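A few compounds are considered here, and "the series" means these few. Any claim that something is new, unique, unknown or untested is made for them only; others in the source may bear on it.

In a functional assay on MCF7 cells (Homo sapiens) for inhibition, read by sulforhodamine B assay, with a stated time of 48 h (on this read-out lower numbers stand for stronger inhibition and higher numbers for weaker inhibition), three related compounds have been measured so far: compound 1 `COc1cc2c(cc1CC1OC1(C)C)C(=O)C[C@@H](c1ccc(O)cc1)O2` gives 30900 nM, compound 2 `COc1cc2c(cc1CC=C(C)C)/C(=N/NC(N)=O)C[C@@H](c1ccc(O)cc1)O2` gives 19500 nM, and compound 3 `COc1ccc([C@@H]2C/C(=N/OCc3cn(-c4ccccc4CO)nn3)c3cc(CC=C(C)C)c(OC)cc3O2)cc1` gives 23400 nM. Compound 3 lies within the usual scatter of both of the others, so its place among these three numbers carries little meaning. All three values sit close together, even though the structures differ in more than one place.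

The next compound to be tested is compound 4 `COc1ccc([C@@H]2C/C(=N/OCc3cn(-c4ccc(C(N)=O)cc4)nn3)c3cc(CC=C(C)C)c(OC)cc3O2)cc1`. It keeps the framework of compound 3 but carries 4-carbamoylphenyl in place of 2-(hydroxymethyl)phenyl on an aromatic nitrogen. Among the compounds with values here, no pair of measured compounds differs in just one place, so the data offer no direct guide to what such a swap does in this assay. The starting point for an expectation is therefore compound 3 at 23400 nM, and no shift beyond the scatter is expected in either direction. The estimated change is small, a 1.1-fold lower number from compound 3 to compound 4 (0.05 log units; within the scatter), and this estimate is uncertain. For compound 4 the expected value is 21000 nM, with an estimated range from 9000 nM to 48000 nM.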

Compound 4, half-maximal inhibitory concentration: 11700 nM
For compound 4 the middle estimate is 1.8-fold (0.25 log units) above the measured one; low and high end bracket the measured number.
By their numbers in this assay, from the lowest: compounds 4, 2, 3 and 1 (each within the scatter of the next, the first and the last beyond it).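

Within the data shown here, compound 3 and compound 4 form the first pair here that differs in only one place, so the group on the aromatic nitrogen of the five-membered ring can now be judged directly in this assay. Putting 4-carbamoylphenyl in place of 2-(hydroxymethyl)phenyl gives a 2.0-fold lower number from compound 3 to compound 4 (0.30 log units; within the scatter), so this read-out does not separate the two groups, although the step is as large as the usual scatter allows. Both groups contain a six-membered aromatic ring of carbon only, and no measurement shown here explains the result or links it to any property of either group.

The swap changes both the substituent and its place on the phenyl ring, so this single pair cannot show what each of those two changes does alone. As far as these compounds go, it also remains open how a plain phenyl, or a phenyl carrying a carboxylic acid or an amine, would read at this nitrogen, and whether any such group would move the number beyond the scatter.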